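A few compounds are considered here, and "the series" means these few. Any claim that something is new, unique, unknown or untested is made for them only; others in the source may bear on it.

Compound 1 `CC(C)C[C@H](NC(=O)CSc1cc(NS(=O)(=O)c2ccccc2)c2ccccc2c1O)B(O)O`: 4160 nM
Compound 2 `CC(=O)Nc1ccc(S(=O)(=O)Nc2cc(SCC(=O)N[C@@H](CC(C)C)B(O)O)c(O)c3ccccc23)cc1`: 8660 nM
Compound 3 `CC(=O)Nc1ccc(S(=O)(=O)Nc2cc(SCCC(=O)N[C@@H](CC(C)C)B(O)O)c(O)c3ccccc23)cc1`: 6620 nM

In a functional assay on MCF7 cells (Homo sapiens) for antiproliferative activity, read by sulforhodamine B assay, with a stated time of 72 h (on this read-out lower numbers stand for stronger inhibition and higher numbers for weaker inhibition), compound 2 gives 8660 nM, at the high end of the measured numbers together with compound 3. Compound 4 `CC(=O)Nc1ccc(S(=O)(=O)Nc2cc(SC(C)C(=O)N[C@@H](CC(C)C)B(O)O)c(O)c3ccccc23)cc1` is not yet measured and alters compound 2 at a single place: methyl in place of hydrogen on a saturated chain carbon bound to a carbonyl carbon and a sulfur. The measured step nearest to this change, on the same chain, is a 1.3-fold lower number from compound 2 to compound 3 (0.12 log units; within the scatter). The other measured step, a 2.1-fold higher number from compound 1 to compound 2 (0.32 log units; beyond the scatter), concerns a different part of the molecule and bears on it little. No step beyond the scatter is therefore expected, and the expected change is a 1.2-fold lower number from compound 2 to compound 4 (0.06 log units; within the scatter). For compound 4 the estimated value is 7500 nM, with an expected range of 4000 nM to 14000 nM.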

Compound 4, half-maximal inhibitory concentration: 8910 nM
Beside the measured number, compound 4's estimate is 1.2-fold (0.07 log units) below it, within the range that was stated.
By their numbers in this assay, from the lowest: compounds 1, 3, 2 and 4 (each within the scatter of the next, the first and the last beyond it).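

In this assay, methyl in place of hydrogen on the saturated chain carbon bound to a carbonyl carbon and a sulfur gives a 1.0-fold higher number from compound 2 to compound 4 (0.01 log units; within the scatter), so this chain carbon carries a methyl without a step beyond the scatter. Earlier, this chain had been varied only in length, with compound 3. Nothing available here accounts for this result. The compounds shown leave open whether a larger group on this carbon, such as isopropyl or phenyl, or an amine there, would also leave the number within the scatter of compound 2.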